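Benzylamino replacing nitro on a weakly active dimethoxy core

The source may hold more compounds than are shown below. What is called first, only, known or untested is meant among the compounds shown, and "the series" means these compounds.

Measured compounds:
Compound 1 `CC(=O)Nc1cc(OCc2ccccc2)nc(SCc2ccccc2)n1`: 40000 nM
Compound 2 `Nc1cc(=O)n(Cc2ccccc2)c(SCc2ccccc2)n1`: 84900 nM
Compound 3 `COc1cc(OC)n2cc(-c3ccc([N+](=O)[O-])cc3)nc2n1`: 70600 nM

All three were tested in a functional assay on LoVo cells (Homo sapiens) for antiproliferative activity, read by MTT assay, with a stated time of 72 h; on this read-out higher numbers stand for weaker inhibition of growth and lower numbers for stronger inhibition of growth. The numbers of compounds 1, 2 and 3 all lie within the usual scatter of one another, so none can be called more or less potent than the rest; compound 3 simply sits among them, with its number closest to that of compound 2.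

Compound 4 `COc1cc(OC)n2cc(-c3ccc(NCc4ccccc4)cc3)nc2n1` is not yet measured. It differs from compound 3 in one place: benzylamino in place of nitro on an aromatic carbon. Among the measured compounds shown here, no measured pair shows this change, so its effect is unknown. The expectation for compound 4 is no step beyond the scatter, with the change from compound 3 to compound 4 estimated at a 1.6-fold lower number from compound 3 to compound 4 (0.20 log units; within the scatter). Compound 4 is therefore expected near 45000 nM, between 12000 nM and 150000 nM.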

Compound 4, concentration for 50% growth inhibition: > 100000 nM
Compound 4 gave a limit, no number (the forecaster's own chance of this, stated with the estimate: 30%); middle value at least 2.2-fold (0.34 log units) away from the limit.
By their numbers in this assay, from the lowest: compounds 1, 3 and 2 (each within the scatter of the next, the first and the last beyond it). At a limit, above all of these: compound 4.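

In this assay, compound 4 gives > 100000 nM, which is a limit of the assay and not a number. Benzylamino in place of nitro on this aromatic carbon, para to a large group, therefore shows no sign of stronger inhibition of growth, with a step of an at least 1.4-fold higher number from compound 3 to compound 4 (0.15 log units; that floor lies within the scatter). The size of the step cannot be read past that floor: the limit of > 100000 nM in this assay, at which 1 of the 4 values shown sits.

From the compounds shown here alone, whether a plain amine or a carboxylic acid on this carbon would give stronger inhibition in this assay remains open. Going by these compounds, it is also open which part of benzylamino, its nitrogen or its ring, goes with this result.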